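The source may hold more compounds than are shown below. What is called first, only, known or untested is meant among the compounds shown, and "the series" means these compounds.

In a functional assay on the whole organism with Rattus norvegicus as the target (a higher number here means that more compound is needed for the effect, a lower number that less compound is needed), three compounds have been measured. Compound 1 `CCOCCOC(=O)C(=O)Nc1nc(-c2cc(OC)no2)cs1` gives 11 mg/kg. Compound 2 `CCOCCOC(=O)C(=O)Nc1nc(-c2cc(C)no2)cs1` gives 1.3 mg/kg; it differs from compound 1 by methyl in place of methoxy on an aromatic carbon, and this change made an 8.5-fold lower number from compound 1 to compound 2 (0.93 log units; beyond the scatter). Compound 3 `COc1cc(-c2csc(NC(=O)C(=O)O)n2)on1` gives 8 mg/kg; its core differs from that of compound 1 by hydrogen in place of 2-ethoxyethyl on an oxygen next to a carbonyl group, which gave only a 1.4-fold lower number from compound 1 to compound 3 (0.14 log units; within the scatter), so the two cores look much alike in this respect.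

Compound 4 `Cc1cc(-c2csc(NC(=O)C(=O)O)n2)on1` has not yet been measured. It differs from compound 3 by methyl in place of methoxy on an aromatic carbon. This is the same change made from compound 1 to compound 2, at the same place, and it occurs twice among these four compounds. The step from compound 3 is expected to be an 8.0-fold lower number from compound 3 to compound 4 (0.90 log units; beyond the scatter), because the identical change gave an 8.5-fold lower number from compound 1 to compound 2 (0.93 log units; beyond the scatter) on a core that differs from the core of compound 3 by a change that stayed within scatter. Within the data shown here, with only one earlier example, the expected step carries uncertainty. Compound 4 is expected to give 1 mg/kg, with a likely range from 0.4 mg/kg to 2.5 mg/kg.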

Compound 4, dose for half-maximal effect: 6 mg/kg
For compound 4 the middle estimate is 6.0-fold (0.78 log units) below the measured one; the whole stated range lies below it.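

In this assay, methyl in place of methoxy on the core of compound 3 gave a 1.3-fold lower number from compound 3 to compound 4 (0.12 log units; within the scatter), so the large gain seen on the core of compound 1 did not carry over: the same change on two cores in this assay, an 8.5-fold lower number (0.93 log units; beyond the scatter) from compound 1 to compound 2 and a 1.3-fold lower number (0.12 log units; within the scatter) from compound 3 to compound 4, 6.3-fold (0.80 log units) apart, beyond the scatter of two such steps Seen from the other side, hydrogen in place of 2-ethoxyethyl made little difference while methoxy was present, but with methyl present it gave a 4.6-fold higher number from compound 2 to compound 4 (0.66 log units; beyond the scatter), so the two changes do not simply add up: the same change on two cores in this assay, a 1.4-fold lower number (0.14 log units; within the scatter) from compound 1 to compound 3 and a 4.6-fold higher number (0.66 log units; beyond the scatter) from compound 2 to compound 4, 6.3-fold (0.80 log units) apart, beyond the scatter of two such steps This shows that, among these four compounds, the effect of one change depends on what stands at the other place, yet it does not show why, nor whether the same holds for any other pair of groups.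

The compounds shown leave open whether another group on the aromatic carbon, such as ethyl or an amine, would also behave differently on the two cores. They also leave open how a shorter or longer chain on the oxygen would compare with 2-ethoxyethyl.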